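Methoxy in place of chloro: compound 1 to compound 4

The source may report more compounds than this note shows. Statements on the series, on what has been measured and on what is new or still open speak of the compounds shown alone.

Measured in a functional assay on HCT-116 cells (Homo sapiens) for cytotoxicity, read by MTT assay, with a stated time of 48 h, in the presence of a further agent that is not named here; on this read-out lower numbers stand for an effect already at smaller amounts and higher numbers for an effect only at larger amounts of compound:
- compound 1 `COc1ccc(-c2cc(NNC(=O)Nc3cc(Cl)nc(Cl)c3)nc3c2cnn3C)cc1`: 12300 nM
- compound 2 `COc1ccc(-c2cc(NNC(=O)Nc3cc(Cl)nc(Cl)c3)nc3c2c(C)nn3C)cc1`: 82300 nM
- compound 3 `CC(C)c1cc(NNC(=O)Nc2cc(Cl)nc(Cl)c2)nc2c1cnn2C`: 17200 nM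

Compound 1 sits at the low end of this short series, a place it shares, within the scatter, with one other compound. The measured steps are a 1.4-fold higher number from compound 1 to compound 3 (0.15 log units; within the scatter) and a 6.7-fold higher number from compound 1 to compound 2 (0.83 log units; beyond the scatter).

Compound 4 `COc1ccc(-c2cc(NNC(=O)Nc3cc(Cl)nc(OC)c3)nc3c2cnn3C)cc1` carries methoxy in place of chloro on an aromatic carbon, turning 2,6-dichloropyridin-4-yl into 2-chloro-6-methoxypyridin-4-yl: methoxy in place of chloro on an aromatic carbon. Both measured steps leave this group untouched, so neither gives a size for this change. No step beyond the scatter is expected in this assay, and no direction is favoured, with compound 1 at 12300 nM as the anchor. The expected step is a 1.2-fold higher number from compound 1 to compound 4 (0.09 log units; within the scatter). For compound 4 the estimated value is 15000 nM, with an expected range of 5000 nM to 45000 nM.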

Compound 4, half-maximal effective concentration: 54200 nM
Estimate against measurement, compound 4: 3.6-fold (0.56 log units) below, and the stated range ends below it.
By their numbers in this assay, from the lowest: compounds 1 and 3 (each within the scatter of the next); then compounds 4 and 2 (each within the scatter of the next).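

In this assay, the 2,6-dichloropyridin-4-yl group proves sensitive to change: methoxy in place of chloro, next to the ring nitrogen, gives a step beyond the scatter (a 4.4-fold higher number from compound 1 to compound 4 (0.64 log units; beyond the scatter)). Among the compounds shown here, the earlier steps all lie elsewhere on the molecule, so this is the only reading on that ring. Chloro gives the lower number of the pair, and no data on hand bear on why.

Open: whether an amine or fluoro at this place behaves like chloro or like methoxy, and whether the remaining chloro tolerates the same change.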